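Exchanging the Amine Substituent of Compound 2

A few compounds are considered here, and "the series" means these few. Any claim that something is new, unique, unknown or untested is made for them only; others in the source may bear on it.

Going by the values given here, in a functional assay on HepG2 cells (Homo sapiens) for inhibition, read by MTT assay, with a stated time of 3 days (on this read-out higher numbers stand for weaker inhibition and lower numbers for stronger inhibition), compound 1 `CC[C@H](C)[C@H](NCC(=O)NNC(=O)COc1ccc(-c2nc3ccccc3s2)cc1OC)C(=O)O` gives 3540 nM and compound 2 `CC[C@H](C)[C@@H](NCC(=O)NNC(=O)COc1ccc(-c2nc3ccccc3s2)cc1OC)C(=O)O` gives 3990 nM on the same scale, so compound 2 stands level with the only other measured compound. The measured step is a 1.1-fold higher number from compound 1 to compound 2 (0.05 log units; within the scatter) and stays within the scatter. All that separates the pair is the fact that compounds 1 and 2 differ only in the configuration as drawn and nothing else.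

Compound 3 `COc1cc(-c2nc3ccccc3s2)ccc1OCC(=O)NNC(=O)CN[C@@H](CS)C(=O)O` carries 1-carboxy-2-sulfanylethyl in place of 1-carboxy-2-methylbutyl on an amine nitrogen, a change that reads in full as 1-carboxy-2-sulfanylethyl in place of 1-carboxy-2-methylbutyl on an amine nitrogen and leaves the shared core untouched. Among the compounds with values here, no measured step covers this exchange. Within the data shown here, the single step available concerns only a stereocentre at a saturated chain carbon, so it bears on the question indirectly at best: it shows that one alteration within this substituent passed without a change beyond the scatter, but it sets no size for replacing the substituent.

With so little to go on, no shift beyond the scatter is expected in either direction, though the uncertainty is wide. The expected change is a 1.1-fold lower number from compound 2 to compound 3 (0.06 log units; within the scatter) in this assay on this reasoning. For compound 3 the estimated value is 3500 nM with an expected range from 1300 nM to 9500 nM as its limits.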

Compound 3, half-maximal inhibitory concentration: 3120 nM
Compound 3: middle estimate off by 1.1-fold (0.05 log units), on the high side; the range from low to high includes it.
By their numbers in this assay, from the lowest: compounds 3, 1 and 2 (each within the scatter of the next).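

In this assay the whole substituent on the amine nitrogen can be exchanged and the number still stays within the scatter: 1-carboxy-2-sulfanylethyl in place of 1-carboxy-2-methylbutyl gives a 1.3-fold lower number from compound 2 to compound 3 (0.11 log units; within the scatter), and the same exchange, read as sulfanylmethyl in place of sec-butyl on a saturated chain carbon bound to an amine nitrogen and a carbonyl carbon, gives a 1.1-fold lower number from compound 1 to compound 3 (0.05 log units; within the scatter). Until now this position had been varied only in configuration; here the entering group has fewer heavy atoms, more hydrogen-bond donors and acceptors, and a sulfur, and no step beyond the scatter follows. The two steps agree, and they start from a pair with a single difference: the fact that compounds 1 and 2 differ only in the configuration as drawn.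

From the compounds shown here alone, all three compounds keep a carboxylic acid on this substituent, so it remains open whether the number would hold with a methyl ester or a primary amide in its place. Going by these compounds alone, also open is whether a side chain carrying a phenyl ring or a terminal amine would produce the first step beyond the scatter at this position.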